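Ethyl for Acetyl on the Urea Aryl Ring

A few compounds are considered here, and "the series" means these few. Any claim that something is new, unique, unknown or untested is made for them only; others in the source may bear on it.

Three ureas on a shared core have been measured in a physicochemical assay for solubility, at pH 7.4; on this read-out higher numbers stand for higher solubility and lower numbers for lower solubility. Compound 1 `CC(=O)c1ccc(NC(=O)Nc2cc(C)nc3ccccc23)cc1` gives 3800 nM and stands second highest of the three. Compound 2 `Cc1cc(NC(=O)Nc2cccc(C(F)(F)F)c2)c2ccccc2n1` gives 100 nM, the lowest number and a large distance below compound 1. Compound 3 `Cc1cc(NC(=O)Nc2cccc(C(C)(C)C)c2)c2ccccc2n1` gives 34700 nM, the highest number, above compound 1 by a smaller but still clear margin. Going by the values given here, the one single-point step among them, tert-butyl in place of trifluoromethyl on an aromatic carbon, is a 350-fold higher number from compound 2 to compound 3 (2.54 log units; beyond the scatter).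

Compound 4 `CCc1ccc(NC(=O)Nc2cc(C)nc3ccccc23)cc1` has not been measured in this assay. It differs from compound 1 as follows: ethyl in place of acetyl on an aromatic carbon. Among the compounds with values here, no measured step concerns an exchange of acetyl for ethyl, and the step from compound 2 to compound 3 involves a different pair of groups, so it gives no direct guide. The only expectation that can rest on the data is that compound 4 should remain in the region of compound 1, since nothing measured points in either direction. Compound 4 is therefore expected to show a 1.3-fold lower number from compound 1 to compound 4 (0.10 log units; within the scatter), within the scatter. The estimated value of compound 4 is 3000 nM, with a range from 700 nM to 13000 nM.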

Compound 4, solubility: 3300 nM
Estimate against measurement, compound 4: 1.1-fold (0.04 log units) below; low and high end bracket the measured number.
By their numbers in this assay, from the lowest: compound 2; then compounds 4 and 1 (each within the scatter of the next); then compound 3.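

In this assay the exchange on this aromatic carbon, para to a large group, gives a 1.2-fold lower number from compound 1 to compound 4 (0.06 log units; within the scatter) and leaves acetyl and ethyl indistinguishable at this position. This holds even though the exchange takes away the double bond and the hydrogen-bond acceptor that acetyl carries, so neither loss shows up as a measurable step in this pair. Going by these compounds alone, the earlier compounds offered only one single-place step, the large 350-fold higher number from compound 2 to compound 3 (2.54 log units; beyond the scatter) and this new pair shows that an exchange of groups on the urea aryl ring can also come with no step beyond the scatter, although no measurement at hand says what lies behind either result.

What the compounds shown leave open is whether a group of another kind on this carbon, such as an amine, a carboxylic acid or a longer chain like butyl, would stay in the region of compound 1 or move away from it. They also leave open whether tert-butyl or trifluoromethyl on this same carbon would reproduce anything like the wide gap seen between those two groups elsewhere in the series.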